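The compounds below may be only part of what the source reports. "The series", "measured", "known", "first", "only" and "open" are said of these compounds alone.

Measured compounds:
compound 1, `CC(C)(C)c1cc(NC(=O)Nc2ccc(-c3nc4ccccc4o3)cc2)no1`, 82.6 nM
compound 2, `CC(C)(C)c1cc(NC(=O)Nc2ccc(-c3cn4cccc(Cl)c4n3)cc2)no1`, 353 nM
compound 3, `CC(C)(C)c1cc(NC(=O)Nc2ccc(-c3cn4cc(F)ccc4n3)cc2)no1`, 20.9 nM

In a functional assay on MV4-11 cells (Homo sapiens) for cytotoxicity, read by MTT assay, with a stated time of 72 h (a higher number here means a weaker inhibitor, a lower number a stronger inhibitor), compound 3 gives the lowest number of the three. The nearest is compound 1, whose number is higher by a margin beyond the scatter, and the furthest is compound 2, whose number lies higher still. Compound 3 is thus the strongest inhibitor among the measured compounds.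

Compound 4 `Cc1ccc2nc(-c3ccc(NC(=O)Nc4cc(C(C)(C)C)on4)cc3)cn2c1` keeps the shared core of compound 3 and differs from it by methyl in place of fluoro on an aromatic carbon. For the measured compounds named here, none of the measured compounds differ from one another in only this place, so no earlier pair fixes the size of this exchange. Both groups are single heavy atoms at the same position, and nothing in the measured set points to a large shift either way. The step from compound 3 is therefore expected to be small, a 1.4-fold higher number from compound 3 to compound 4 (0.16 log units; within the scatter), and to stay within the usual scatter. Compound 4 is estimated at 30 nM, with a range from 10 nM to 90 nM.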

Compound 4, half-maximal inhibitory concentration: 4.08 nM
Estimate against measurement, compound 4: 7.4-fold (0.87 log units) above; measured number below the stated range.
By their numbers in this assay, from the lowest: compound 4; then compound 3; then compound 1; then compound 2.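

In this assay, methyl in place of fluoro on this aromatic carbon gives a 5.1-fold lower number from compound 3 to compound 4 (0.71 log units; beyond the scatter), so this place, two atoms from the ring nitrogen, responds clearly to the exchange of one single heavy atom for another. For the compounds shown here, this is the first comparison in the set in which two compounds differ in one place only, and it gives this exchange a size that the earlier compounds could not fix. No measurement at hand accounts for the step.

The compounds shown leave open how an unsubstituted carbon, or a methoxy group, an ethyl group or an amine, would compare with fluoro and methyl at this same place. They also leave open whether this exchange would produce a step of similar size on another carbon of the same ring.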